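The source may report more compounds than this note shows. Statements on the series, on what has been measured and on what is new or still open speak of the compounds shown alone.

Measured in a functional assay (Hippocampus) with Rattus norvegicus as the target; a higher number here means a more potent compound, by a factor of ten per unit of this negative logarithm, a lower number a less potent compound:
Compound 1 `COC(=O)C1CC2CC1N(C)C2`: 5.4
Compound 2 `COC(=O)[C@@H]1C[C@@H]2C[C@H]1N(C)C2`: 5.9

Of these two, compound 2 stands highest, at 5.9. The next compound, compound 3 `COC(=O)[C@H]1C[C@H]2C[C@@H]1N(C)C2`, has not yet been measured. It relates to compound 2 as follows: the two compounds have the same atoms and bonds and differ only in configuration as drawn: 3 of 3 stereo elements differ (all stereocentres are inverted: mirror images); a stereocentre at a saturated ring carbon is drawn R in compound 2 and S in compound 3; a stereocentre at a saturated ring carbon is drawn R in compound 2 and S in compound 3; a stereocentre at a saturated ring carbon is drawn R in compound 2 and S in compound 3. Within the data shown here, the only measured step that bears on this change is a number 0.50 log units higher from compound 1 to compound 2 (beyond the scatter), and what separates that pair is the fact that one of compounds 1 and 2 is drawn with a defined configuration and the other without, at the place where they differ. Compound 1 has no configuration drawn, so it may contain compound 3 alongside compound 2. If so, the lower value of compound 1 at 5.4 suggests that the mirror image contributes little, and a drop larger than that step is expected in this assay. The expected change is estimated as a number 1.20 log units lower from compound 2 to compound 3 (beyond the scatter). For compound 3 the estimated value is 4.7, with an expected range of 4 to 5.4.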

Compound 3, negative logarithm of the half-maximal effective concentration: < 4
Compound 3 ended at the assay's limit (the forecaster's own chance of this, stated with the estimate: 25%); middle value at least 0.70 log units from the limit.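

In this assay compound 3 gives < 4, which is a limit of the assay and not a number. The earlier pair showed only a modest gain on defining the configuration, whereas full inversion of all three stereocentres, with no atom added or removed, now reads as a number at least 1.90 log units lower from compound 2 to compound 3 (beyond the scatter), so the configuration of the shared core decides the result here: the fact that compounds 2 and 3 differ only in the configuration as drawn The compound drawn without configuration also stands clear of the inverted form, with a number at least 1.40 log units lower from compound 1 to compound 3 (beyond the scatter): the fact that one of compounds 1 and 3 is drawn with a defined configuration and the other without, at the place where they differ

As far as these compounds go, the true size of both steps remains open, since compound 3 sits at a limit, and so does the make-up of compound 1. From the compounds shown here alone, it is also open whether the same preference for one mirror image would hold with a carboxylic acid in place of the methyl ester, or with a longer chain in place of the methyl on nitrogen.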